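The source may report more compounds than this note shows. Statements on the series, on what has been measured and on what is new or still open speak of the compounds shown alone.

Compound 1 `Cc1ccc(=O)n(CCCCCC(=N)S)n1` gives 36.6%.
Compound 2 `Cc1ccc(=O)n(CCCCCCC(=N)S)n1` gives 29.5%.
Compound 3 `N=C(S)CCn1nc(-c2ccccc2)ccc1=O` gives 53.7%.

All three numbers come from a functional assay on the whole organism (stomach) for inhibition, with Rattus norvegicus as the target, at a dose of 100 mg/kg by the intraduodenal route; on this read-out higher numbers stand for more inhibition at the one dose given (going by the name of the read-out) and lower numbers for less inhibition. In this assay compound 3 gives the highest of the three numbers, and its distance to compound 1 and to compound 2 is beyond the scatter. The core of compound 3 is not the core of compound 2; the difference between the two cores is not broken down here. Compound 2 and compound 1 differ by a group of 3 heavy atoms (1 carbon, 1 nitrogen, 1 sulfur; no ring) in place of a group of 4 heavy atoms (2 carbon, 1 nitrogen, 1 sulfur; no ring), on a saturated chain carbon, five bonds along the chain from an aromatic nitrogen, and this step gave a number 7.1 percentage points higher from compound 2 to compound 1 (within the scatter).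

Compound 4 `N=C(S)Cn1nc(-c2ccccc2)ccc1=O` has not yet been measured. It differs from compound 3 by a group of 3 heavy atoms (1 carbon, 1 nitrogen, 1 sulfur; no ring) in place of a group of 4 heavy atoms (2 carbon, 1 nitrogen, 1 sulfur; no ring), on a saturated chain carbon bound to an aromatic nitrogen. Among the compounds with values here, this is the same kind of change as the one from compound 2 to compound 1, not the same change: there the group sat on a saturated chain carbon five bonds along the chain from an aromatic nitrogen, here it sits on a saturated chain carbon bound to an aromatic nitrogen. The earlier step stayed within the scatter, so the step expected here is a number 3.7 percentage points lower from compound 3 to compound 4 (within the scatter). Compound 4 is therefore estimated at 50%, most likely between 35% and 65%.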

Compound 4, a percentage reported as inhibition, in the whole organism at one dose (the size of the read-out at that dose, not a potency): 5.5%
For compound 4 the middle estimate is 44.5 percentage points above the measured one, outside the stated range (below it).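

In this assay, the group with one carbon fewer gave a number 48.2 percentage points lower from compound 3 to compound 4 (beyond the scatter). Set beside the earlier step, this change did not carry over from one core to the other: the same change on two cores in this assay, a number 7.1 percentage points higher (within the scatter) from compound 2 to compound 1 and a number 48.2 percentage points lower (beyond the scatter) from compound 3 to compound 4, 55.3 percentage points apart, beyond the scatter of two such steps So a step seen on one core cannot simply be transferred to the other, but the reason remains unshown: the two steps also sit at different places on the chain, and each core offers only one such pair.

Going by these compounds, whether a longer chain on the core of compound 3 would raise or lower the number stays open. So does what an amine or a carboxylic acid would give in place of the group at the chain end.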